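Amide-nitrogen substituent swap on the nitro-bearing series

The source may report more compounds than this note shows. Statements on the series, on what has been measured and on what is new or still open speak of the compounds shown alone.

Measured so far:
- compound 2 `O=C(Cn1c(=O)oc2cc([N+](=O)[O-])ccc21)Nc1ccccn1` — 47.3%
- compound 3 `O=C(Cn1c(=O)oc2cc(Cl)ccc21)Nc1ccccn1` — 43.7%
- compound 1 `O=C(Cn1c(=O)oc2cc([N+](=O)[O-])ccc21)Nc1cc(C(F)(F)F)ccc1Cl` — 31.6%

In an ADME assay on RAW264.7 cells (Mus musculus) for cytotoxicity, read by MTT assay, with a stated time of 72 h, tested at 100 uM (on this read-out lower numbers stand for a weaker effect and higher numbers for a stronger effect at the one concentration tested), compound 2 gives 47.3%, the highest of the three numbers. Compound 3 sits nearest, with a number 3.6 percentage points lower from compound 2 to compound 3 (within the scatter) lying within the scatter. Compound 1 is furthest, beyond the scatter, and since compound 1 and compound 2 share the same core and differ only in the group on the amide-type nitrogen, their two values show that a change at this nitrogen can move the read-out by more than the scatter.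

Compound 4 `O=C(Cn1c(=O)oc2cc([N+](=O)[O-])ccc21)NCc1ccco1` differs from compound 2 by (furan-2-yl)methyl in place of pyridin-2-yl on an amide-type nitrogen. Among the compounds with values here, no measured single-place step touches the amide-type nitrogen; the one step available, from compound 2 to compound 3, concerns an aromatic carbon and does not bear on this change. The pair compound 1 and compound 2 only indicates that the size of such a step may exceed the scatter, without fixing a direction.

Compound 4 is therefore expected to land near compound 2, with the estimated step of a number 7.3 percentage points lower from compound 2 to compound 4 (within the scatter) modest and downward, and a wide range. The estimate for compound 4 is 40%, between 24% and 56%.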

Compound 4, a percentage reported as inhibition, at one concentration (the size of the read-out at that concentration, not a potency): 60.1%
The estimate for compound 4 lay 20.1 percentage points below the measured number; the measured number lies above the stated range.
By their numbers in this assay, from the lowest: compound 1; then compounds 3 and 2 (each within the scatter of the next); then compound 4.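

In this assay, (furan-2-yl)methyl in place of pyridin-2-yl on the amide-type nitrogen gives a number 12.8 percentage points higher from compound 2 to compound 4 (beyond the scatter) on the nitro-bearing shared core. This gives a direction for this one change, which compound 1 and compound 2 alone did not provide for the step to (furan-2-yl)methyl. With compound 1 at 31.6% and compound 4 at 60.1%, the printed values also show a wider spread for groups on this nitrogen than the first two amides showed, and no measurement on hand accounts for the rise in the read-out.

The change replaces a six-membered aromatic ring bonded directly to the amide-type nitrogen with a five-membered aromatic ring attached through a methyl link, so the compounds shown do not separate the ring from the link, a question that (pyridin-2-yl)methyl or benzyl on the same nitrogen would address. It also remains open whether (furan-2-yl)methyl has the same effect on the chloro-bearing core of compound 3, where only pyridin-2-yl is shown on this nitrogen.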